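Methoxy for hydroxy on a pyrazole urea scaffold

The source may report more compounds than this note shows. Statements on the series, on what has been measured and on what is new or still open speak of the compounds shown alone.

Compound 1 `O=C(Nc1cccc(-n2cc(-c3ccncc3)c(-c3cc(O)cc(Cl)c3)n2)c1)Nc1ccc(Cl)c(Cl)c1` was tested in a functional assay on HOP-62 cells (Homo sapiens) for inhibition, read by sulforhodamine B assay, with a stated time of 48 h, tested at 0.01 uM (on this read-out higher numbers stand for a weaker effect at the one concentration tested and lower numbers for a stronger effect), and in that assay compound 1 gives 105%, the higher of the two numbers recorded here. Compound 2 `COc1cc(Cl)cc(-c2nn(-c3cccc(NC(=O)Nc4cc(C(F)(F)F)cc(C(F)(F)F)c4)c3)cc2-c2ccncc2)c1` carries a methoxy group and a different urea aryl, and in this assay compound 2 gives 93%, a number lower than that of compound 1 by more than the usual scatter. Compound 3 `COc1cc(Cl)cc(-c2nn(-c3cccc(NC(=O)Nc4ccc(Cl)c(Cl)c4)c3)cc2-c2ccncc2)c1` has not yet been measured. It differs from compound 1 in one place: methyl in place of hydrogen on an oxygen on an aromatic ring. For the measured compounds named here, no measured pair shows this change on its own, so its size is unknown; since the two compounds measured so far bracket a narrow span, the step from compound 1 to compound 3 is expected to be small, likely none beyond the scatter, or at most a slight drop, as a number 7 percentage points lower from compound 1 to compound 3 (within the scatter). Compound 3 is therefore estimated at 98%, with a range from 85% to 110%.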

Compound 3, a percentage reported as activity, at one concentration (the size of the read-out at that concentration, not a potency): 92%
Estimate against measurement, compound 3: 6 percentage points above, and the stated range covers the measured number.
By their numbers in this assay, from the lowest: compounds 3 and 2 (each within the scatter of the next); then compound 1.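

For the compounds shown here, compound 3 shows the change from hydroxy to methoxy on its own for the first time: in this assay, methyl in place of hydrogen on an oxygen on an aromatic ring gives a number 13 percentage points lower from compound 1 to compound 3 (beyond the scatter), a modest step toward a stronger effect. Going by these compounds alone, compound 2 carries the methoxy group together with a different urea aryl, so only this pair ties a step to the oxygen alone. Nothing shown here gives a reason for the step.

Going by these compounds, whether a longer chain such as ethoxy on this oxygen, or an amine or a carboxylic acid in place of the hydroxy, would move the number further remains open. The read-out also comes from one concentration on one cell line, so it leaves open whether the step would carry over to a potency or to other cells.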